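The compounds below may be only part of what the source reports. "The series", "measured", "known", "first", "only" and "open" are said of these compounds alone.

Compound 3 `COc1ccc(C(=O)/C=C/c2ccc(OCc3cn(Cc4ccc(Br)cc4)nn3)cc2)cc1` carries a 4-bromophenyl group on a saturated chain carbon bound to an aromatic nitrogen. In a functional assay on HepG2 cells (Homo sapiens) for inhibition, read by MTT assay, with a stated time of 48 h, tested at 10 uM (on this read-out lower numbers stand for less inhibition of growth and higher numbers for more inhibition of growth at the one concentration tested), compound 3 gives 59%, the highest of the three numbers measured. Compound 1 `COc1ccc(C(=O)/C=C/c2ccc(OCc3cn(Cc4ccccc4Br)nn3)cc2)cc1`, with a 2-bromophenyl group in that place, gives 44%, and compound 2 `COc1ccc(C(=O)/C=C/c2ccc(OCc3cn(Cc4cccc(Br)c4)nn3)cc2)cc1`, with a 3-bromophenyl group, gives 27%. The step of a number 15 percentage points higher from compound 1 to compound 3 (beyond the scatter) and the step of a number 32 percentage points higher from compound 2 to compound 3 (beyond the scatter) both lie beyond the scatter, so the placement of the bromine on this ring changes the read-out. Compound 4 `COc1ccc(C(=O)/C=C/c2ccc(OCc3cn(Cc4ccccc4F)nn3)cc2)cc1` differs from compound 3 by 2-fluorophenyl in place of 4-bromophenyl on a saturated chain carbon bound to an aromatic nitrogen. Among the compounds with values here, two things change at once: the ring takes the placement seen in the 2-bromophenyl of compound 1, and bromine becomes fluorine; no measured pair shows the halogen swap alone. Because the step of a number 15 percentage points higher from compound 1 to compound 3 (beyond the scatter) was modest, undoing that placement is expected to lower the number, while the halogen swap adds uncertainty. The step of a number 19 percentage points lower from compound 3 to compound 4 (beyond the scatter) is therefore expected to be modest and downward. Compound 4 is expected to give 40%, within a range from 22% to 58%.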

Compound 4, percent growth inhibition at one concentration: 33%
Beside the measured number, compound 4's estimate is 7 percentage points above it; the range from low to high includes it.
By their numbers in this assay, from the lowest: compounds 2 and 4 (each within the scatter of the next); then compound 1; then compound 3.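

Within the data shown here, the step (a number 11 percentage points lower from compound 1 to compound 4 (beyond the scatter)) is the first reading of fluoro in place of bromo on an aromatic carbon with nothing else changed, so at this position the identity of the halogen matters as well as its placement. The step (a number 26 percentage points lower from compound 3 to compound 4 (beyond the scatter)) combines that swap with a move away from the 4-bromophenyl pattern, so the two changes cannot be cleanly separated within it. The step (a number 6 percentage points higher from compound 2 to compound 4 (within the scatter)) shows that in this assay a 2-fluorophenyl group and a 3-bromophenyl group give numbers that cannot be told apart.

On these data alone, how chloro, an amine or a carboxylic acid on this ring would read remains open, as does the effect of a longer chain in place of the saturated chain carbon. Nothing at hand explains why these steps arise.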